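The compounds below may be only part of what the source reports. "The series", "measured", "known", "first", "only" and "open" are said of these compounds alone.

Going by the values given here, in an assay on isolated protein for inhibition of Amine oxidase [flavin-containing] B (Homo sapiens), read by fluorescence and Amplex Red, with stated times of 15 min and 20 min (a higher number here means a weaker inhibitor, a lower number a stronger inhibitor), compound 1 `Oc1ccc(O)c(/C=N/c2ccc(OCc3ccccc3)cc2)c1` gives 1230 nM, the lowest of the three numbers measured so far. Compound 2 `Oc1ccc(F)cc1/C=N/c1ccc(OCc2ccccc2)cc1` gives 15300 nM, and compound 3 `Cc1ccc(O)c(/C=N/c2ccc(OCc3ccccc3)cc2)c1` gives 24600 nM. Compound 4 `Oc1ccc(Cl)cc1/C=N/c1ccc(OCc2ccccc2)cc1` has not yet been measured; it differs from compound 1 by chloro in place of hydroxy on an aromatic carbon. Two measured steps start from the same hydroxy group of compound 1: a 12-fold higher number from compound 1 to compound 2 (1.09 log units; beyond the scatter), and a 20-fold higher number from compound 1 to compound 3 (1.30 log units; beyond the scatter). Both replacements of that hydroxy group raised the number by a large amount, and the two products differ only by a 1.6-fold higher number from compound 2 to compound 3 (0.21 log units; within the scatter). A chloro group at the same place is therefore expected to behave alike, so compound 4 is estimated at 16000 nM, within a range of 5000 nM to 50000 nM. That expectation amounts to a 13-fold higher number from compound 1 to compound 4 (1.11 log units; beyond the scatter).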

Compound 4, half-maximal inhibitory concentration: 24800 nM
The estimate for compound 4 lay 1.6-fold (0.19 log units) below the measured number, and the stated range covers the measured number.
By their numbers in this assay, from the lowest: compound 1; then compounds 2, 3 and 4 (each within the scatter of the next).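

With a 20-fold higher number from compound 1 to compound 4 (1.30 log units; beyond the scatter) for chloro in place of hydroxy, a third, different replacement of this hydroxy group also gives a large step. Chloro does not stand apart from the other two replacements: a 1.0-fold higher number from compound 3 to compound 4 (0.00 log units; within the scatter) and a 1.6-fold higher number from compound 2 to compound 4 (0.21 log units; within the scatter) are both small steps, so among these four compounds only the hydroxy group of compound 1 gives a clearly lower number. Whether an amine or a methoxy group at this place would stay close to compound 1 remains open, and nothing measured here offers an explanation for the gap.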